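The compounds below may be only part of what the source reports. "The series", "measured", "known", "first", "only" and "open" are said of these compounds alone.

Going by the values given here, in a functional assay on OCI-Ly3 cells (Homo sapiens) for antiproliferative activity (a lower number here means that less compound is needed, a higher number that more compound is needed for the effect), compound 1 `O=C(Nc1cnc(-n2nccn2)c(Cl)c1)Nc1cnc2ccccc2c1C1CCCC1` gives 7020 nM, while compound 2 `COC(C)c1c(NC(=O)Nc2cnc(-n3nccn3)c(Cl)c2)cnc2ccccc12` gives 620 nM, the lower of the only two numbers measured so far. Compound 3 `COC(C)(C)c1c(NC(=O)Nc2cnc(-n3nccn3)c(Cl)c2)cnc2ccccc12` differs from compound 2 in one place, where 1-methoxyethyl becomes 1-methoxy-1-methylethyl: methyl in place of hydrogen on a saturated chain carbon bound to an aromatic carbon, an oxygen on a saturated carbon and a saturated chain carbon. Put simply, methyl replaces hydrogen on a saturated chain carbon bound to an aromatic carbon, an oxygen on a saturated carbon and a saturated chain carbon.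

Among the compounds with values here, no measured step covers this exact change. The nearest evidence is an 11-fold lower number from compound 1 to compound 2 (1.05 log units; beyond the scatter), a large step beyond the scatter. It bears on the new change only loosely, since it exchanged one whole group for another, whereas compound 3 keeps the 1-methoxyethyl skeleton and adds a single methyl. A much smaller effect therefore seems likely, with no firm direction. The expected result in this assay is a 1.2-fold lower number from compound 2 to compound 3 (0.09 log units; within the scatter), which means no step beyond the scatter is anticipated. The estimated value for compound 3 is 500 nM, with an expected range from 150 nM to 1700 nM.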

Compound 3, half-maximal effective concentration: 4430 nM
Compound 3: the middle estimate sits 8.9-fold (0.95 log units) below what was measured; measured number above the stated range.
By their numbers in this assay, from the lowest: compound 2; then compounds 3 and 1 (each within the scatter of the next).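

In this assay, one added methyl on the saturated chain carbon bound to an aromatic carbon is enough to change the result: going from 1-methoxyethyl to 1-methoxy-1-methylethyl gives a 7.1-fold higher number from compound 2 to compound 3 (0.85 log units; beyond the scatter). Going by these compounds alone, the earlier pair showed only that exchanging a whole group at this place can matter, whereas this step shows that a single extra carbon can matter too, so the advantage of 1-methoxyethyl over cyclopentyl does not carry over to every ether-bearing group here: 1-methoxy-1-methylethyl in place of cyclopentyl gives only a 1.6-fold lower number from compound 1 to compound 3 (0.20 log units; within the scatter), which leaves those two compounds unseparated. The hydrogen on that chain carbon is therefore not a place where added carbon can be assumed harmless, and nothing measured here explains why.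

The compounds shown leave open whether the methoxy oxygen is needed at all, a question that a plain ethyl or isopropyl group on the same aromatic carbon would address. They also leave open how a 1-hydroxyethyl group or an amine on that chain carbon would read in this assay.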